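From Nitrile to Methyl: Estimating Compound 4

A few compounds are considered here, and "the series" means these few. Any claim that something is new, unique, unknown or untested is made for them only; others in the source may bear on it.

Three measured compounds share one core and differ in a single group. Compound 1 `CN(Cc1ccc2nccn2c1)c1nnc(-c2ccc(C3CC3)cc2)o1` carries a cyclopropyl, and in an assay on isolated protein for inhibition of tyrosine-protein kinase receptor UFO (Homo sapiens), read by LC-MS (on this read-out lower numbers stand for stronger inhibition and higher numbers for weaker inhibition), compound 1 gives 20000 nM. Compound 2 `CN(Cc1ccc2nccn2c1)c1nnc(-c2ccc(-c3ccccc3F)cc2)o1` carries a 2-fluorophenyl instead, and in this assay compound 2 gives 1580 nM. That exchange is a large step: a 13-fold lower number from compound 1 to compound 2 (1.10 log units; beyond the scatter). Compound 3 `CN(Cc1ccc2nccn2c1)c1nnc(-c2ccc(-c3ccccc3C#N)cc2)o1` carries a 2-cyanophenyl, and in this assay compound 3 gives 3980 nM, the second highest of the three numbers. Its steps are a 5.0-fold lower number from compound 1 to compound 3 (0.70 log units; beyond the scatter) and a 2.5-fold higher number from compound 2 to compound 3 (0.40 log units; beyond the scatter), both beyond the scatter but the second only modest.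

Compound 4 `Cc1ccccc1-c1ccc(-c2nnc(N(C)Cc3ccc4nccn4c3)o2)cc1` is not yet measured. It differs from compound 3 by methyl in place of cyano on an aromatic carbon. Going by the values given here, no measured step swaps cyano for methyl, so the guide is indirect. The exchange of one small group for another on the attached phenyl gave a modest shift, a 2.5-fold higher number from compound 2 to compound 3 (0.40 log units; beyond the scatter), while the presence of the phenyl itself gave the large shifts a 13-fold lower number from compound 1 to compound 2 (1.10 log units; beyond the scatter) and a 5.0-fold lower number from compound 1 to compound 3 (0.70 log units; beyond the scatter). A modest downward step is therefore expected, about a 1.8-fold lower number from compound 3 to compound 4 (0.26 log units; within the scatter). In this assay compound 4 is expected to give roughly 2200 nM, with a range from 800 nM to 6000 nM.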

Compound 4, half-maximal inhibitory concentration: 631 nM
For compound 4 the middle estimate is 3.5-fold (0.54 log units) above the measured one; the whole stated range lies above it.
By their numbers in this assay, from the lowest: compound 4; then compound 2; then compound 3; then compound 1.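

Going by these compounds alone, at this carbon, ortho to a large group, the choice of small group matters more than the earlier compounds could show: in this assay there is a 6.3-fold lower number from compound 3 to compound 4 (0.80 log units; beyond the scatter) when methyl replaces cyano, a larger shift than a 2.5-fold higher number from compound 2 to compound 3 (0.40 log units; beyond the scatter) seen when cyano replaced fluoro. Methyl also outdoes fluoro, with a 2.5-fold lower number from compound 2 to compound 4 (0.40 log units; beyond the scatter) as the result, so the three groups now fall into a clear order in which methyl gives the lowest number, fluoro the next and cyano the highest, and a group with fewer heavy atoms and no hydrogen-bond acceptor gives the lowest number of all. Measured against the cyclopropyl of the first compound, the 2-methylphenyl gives a 32-fold lower number from compound 1 to compound 4 (1.50 log units; beyond the scatter) and is the largest gain in the set, which shows that the attached ring alone does not set the size of the gain and that its small group counts as well.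

Going by these compounds, whether an ethyl, a methoxy or an amine on this same carbon would lower the number further or raise it again stays open. Nothing measured here says why methyl gives the lowest number of these groups.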